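The source may hold more compounds than are shown below. What is called first, only, known or untested is meant among the compounds shown, and "the series" means these compounds.

Compound 1 `CC(C)(C)c1ccc(N/C(=N\C(=O)c2ccccc2)NCc2ccccc2)cc1`: 1120000 nM
Compound 2 `COc1ccc(N/C(=N\C(=O)c2ccccc2)NCc2ccccc2)cc1`: 837000 nM
Compound 3 `O=C(/N=C(/NCc1ccccc1)Nc1ccc([N+](=O)[O-])cc1)c1ccccc1`: 802000 nM

These three compounds share one core and differ only in a single group on an aromatic carbon. All were tested in an ADME assay on cells (Peritoneal macrophage, Mus musculus) for cytotoxicity, read by MTT assay, with a stated time of 24 h; on this read-out lower numbers stand for higher toxicity in this test and higher numbers for lower toxicity in this test. Compound 3 gives 802000 nM, a number within the usual scatter of the values for both of the other compounds.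

The next compound, not yet measured, is compound 4 `O=C(/N=C(/NCc1ccccc1)Nc1ccc(I)cc1)c1ccccc1`. To reach it from compound 3, iodo takes the place of nitro on an aromatic carbon, para to a large group: iodo in place of nitro on an aromatic carbon.

Among the compounds with values here, three measured steps bear on this change, each a swap of one group for another at that same place: a 1.3-fold lower number from compound 1 to compound 2 (0.13 log units; within the scatter), a 1.4-fold lower number from compound 1 to compound 3 (0.15 log units; within the scatter) and a 1.0-fold lower number from compound 2 to compound 3 (0.02 log units; within the scatter). All three are small and lie within the scatter, so the three numbers cannot be told apart. None of these compounds carries iodo, however, so the new group itself is untested.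

No step beyond the scatter is expected in this assay, in either direction. The estimated change is a 1.1-fold higher number from compound 3 to compound 4 (0.06 log units; within the scatter), which is expected to stay within the scatter. For compound 4 the expected value is 920000 nM, with an estimated range from 480000 nM to 1750000 nM.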

Compound 4, half-maximal cytotoxic concentration: 619000 nM
The estimate for compound 4 lay 1.5-fold (0.17 log units) above the measured number, within the range that was stated.
By their numbers in this assay, from the lowest: compounds 4, 3, 2 and 1 (each within the scatter of the next).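

In this assay, iodo in place of nitro gives a 1.3-fold lower number from compound 3 to compound 4 (0.11 log units; within the scatter), iodo in place of methoxy gives a 1.4-fold lower number from compound 2 to compound 4 (0.13 log units; within the scatter), and iodo in place of tert-butyl gives a 1.8-fold lower number from compound 1 to compound 4 (0.26 log units; within the scatter). Iodo has no hydrogen-bond acceptors, whereas nitro has some, yet this swap at the same aromatic carbon still does not produce a step beyond the scatter, and even the step from tert-butyl to iodo stays within it, so the four compounds cannot be told apart in this test. No measurement of any other property is available to bear on this result.

The compounds shown leave open whether a group of another kind on this aromatic carbon, such as an amine, a carboxylic acid or a longer chain, would give a step beyond the scatter. They also leave open whether changes elsewhere on the shared core would move the number, since all four compounds differ only at this one place.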